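A Phenyl Group Replaces Trifluoromethyl

The source may report more compounds than this note shows. Statements on the series, on what has been measured and on what is new or still open speak of the compounds shown alone.

In a functional assay (mast cells) for inhibition, with Rattus norvegicus as the target (on this read-out lower numbers stand for an effect already at smaller amounts and higher numbers for an effect only at larger amounts of compound), compound 1 `CCOC(=O)c1cnc2n(c1=O)C(C)CC/C2=N\Nc1ccc(C(=O)O)cc1` gives 66000 nM, compound 2 `O=C(O)c1cnc2n(c1=O)CCC/C2=N\Nc1ccccc1` gives 2900 nM and compound 3 `CC1CC/C(=N\Nc2ccc(C(F)(F)F)cc2)c2ncc(C(=O)O)c(=O)n21` gives 280 nM. Compound 3 has the lowest number of the three, so it shows its effect at the smallest amount. Compound 4 `CC1CC/C(=N\Nc2ccc(-c3ccccc3)cc2)c2ncc(C(=O)O)c(=O)n21` keeps the core of compound 3 but carries phenyl in place of trifluoromethyl on an aromatic carbon. Among the measured compounds shown here, no two measured compounds differ in only one place, so the data offer no direct guide to this swap. The expected change is a 1.3-fold higher number from compound 3 to compound 4 (0.10 log units; within the scatter), which is no step beyond the usual scatter, and its direction is uncertain. For compound 4 the estimated value is 350 nM, with an expected range from 80 nM to 1500 nM.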

Compound 4, half-maximal effective concentration: 4400 nM
Compound 4: the middle estimate sits 13-fold (1.10 log units) below what was measured; measured number above the stated range.
By their numbers in this assay, from the lowest: compound 3; then compounds 2 and 4 (each within the scatter of the next); then compound 1.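

In this assay, the swap of trifluoromethyl for phenyl, on an aromatic carbon para to a large group, gives a 16-fold higher number from compound 3 to compound 4 (1.20 log units; beyond the scatter). Among the compounds shown here, this is the first comparison here that changes one place only, and it shows that the group at this position matters: a group with no ring and 4 heavy atoms gives way to an aromatic ring with 6, and the number rises well beyond the scatter. Nothing available here explains why. From the compounds shown here alone, how a methoxy group, a chlorine atom or a nitrile would behave at this position remains open.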